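Acetyl to propanoyl on a dimeric acylphloroglucinol

The source may hold more compounds than are shown below. What is called first, only, known or untested is meant among the compounds shown, and "the series" means these compounds.

Compound 1 `CC(=O)C1=C(O)C(C)(C)C(O)=C(CC2=C(O)C(C)(C)C(O)=C(C(C)=O)C2=O)C1=O`: > 50 ug/mL
Compound 2 `CCC(=O)C1=C(O)C(C)(C)C(O)=C(Cc2c(O)c3c(c(C(C)=O)c2O)OC(C)(C)C=C3)C1=O`: 1.9 ug/mL

In a functional assay on P388 cells (Mus musculus) for cytotoxicity, with a stated time of 48 h (on this read-out higher numbers stand for an effect only at larger amounts of compound and lower numbers for an effect already at smaller amounts), compound 1 gives only a limit, > 50 ug/mL. Among the measured compounds shown here, compound 2 gives the only actual number in this assay, 1.9 ug/mL. The other value shown, that of compound 1, is a limit of the assay (the limit of > 50 ug/mL in this assay, at which 1 of the 2 values shown sits). Compound 3 `CCC(=O)C1=C(O)C(C)(C)C(O)=C(Cc2c(O)c3c(c(C(=O)CC)c2O)OC(C)(C)C=C3)C1=O` differs from compound 2 by methyl in place of hydrogen on a saturated chain carbon bound to a carbonyl carbon. For the measured compounds named here, no measured pair shows this change, so the step is expected to stay within the usual scatter, with no direction claimed: a 1.1-fold higher number from compound 2 to compound 3 (0.02 log units; within the scatter). Compound 3 is therefore estimated at 2 ug/mL in this assay, between 0.8 ug/mL and 5 ug/mL.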

Compound 3, concentration for half-maximal effect: 2.1 ug/mL
Estimate against measurement, compound 3: 1.1-fold (0.02 log units) below; measured number inside the range.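

Among the compounds shown here, the step gives the first reading of this change at this position. In this assay, methyl in place of hydrogen on a saturated chain carbon bound to a carbonyl carbon, which turns acetyl into propanoyl, gives a 1.1-fold higher number from compound 2 to compound 3 (0.04 log units; within the scatter), so this position accepts the added methyl without a change beyond the scatter. Nothing shown here gives a reason for this result.

The compounds shown leave open whether a longer chain, such as butanoyl, would behave the same way in this assay. They also leave open what an amine or a carboxylic acid on this chain carbon would do.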